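Hydrazone-urea series: pyrrolidinyl for dimethylamino on the propyl chain

A few compounds are considered here, and "the series" means these few. Any claim that something is new, unique, unknown or untested is made for them only; others in the source may bear on it.

Measured compounds in a functional assay on A549 cells (Homo sapiens) for antiproliferative activity, read by MTT assay, with a stated time of 72 h; on this read-out lower numbers stand for stronger inhibition and higher numbers for weaker inhibition:
compound 1 `O=C(N/N=C/c1ccc(O)cc1)Nc1ccc(Oc2ccnc3[nH]ccc23)cc1`: 1910 nM
compound 2 `CN(C)CCn1cccc1/C=N/NC(=O)Nc1ccc(Oc2ccnc3[nH]ccc23)cc1`: "not active" (no number reported)
compound 3 `CN(C)CCCn1cccc1/C=N/NC(=O)Nc1ccc(Oc2ccnc3[nH]ccc23)cc1`: 2660 nM

Compound 3 has the highest number of the two reported values; its nearest neighbour is compound 1, with a 1.4-fold higher number from compound 1 to compound 3 (0.14 log units; within the scatter), a step within the scatter. Compound 2 is reported without a number.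

Compound 4 `O=C(N/N=C/c1cccn1CCCN1CCCC1)Nc1ccc(Oc2ccnc3[nH]ccc23)cc1` differs from compound 3 by pyrrolidin-1-yl in place of dimethylamino on a saturated chain carbon, three bonds along the chain from an aromatic nitrogen. Among the compounds with values here, no measured step in this set touches this part of the chain; the single step that exists, from compound 1 to compound 3, changes a different portion and was within the scatter. No step beyond the scatter is therefore expected for a 1.1-fold lower number from compound 3 to compound 4 (0.03 log units; within the scatter) in this assay. Compound 4 is estimated at 2500 nM, with a range from 1200 nM to 5500 nM.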

Compound 4, half-maximal inhibitory concentration: 1300 nM
For compound 4 the middle estimate is 1.9-fold (0.28 log units) above the measured one; the range from low to high includes it.
By their numbers in this assay, from the lowest: compounds 4, 1 and 3 (each within the scatter of the next, the first and the last beyond it).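

In this assay, within the data shown here, the end of the propyl chain proves responsive to change: pyrrolidin-1-yl in place of dimethylamino gives a modest shift (a 2.0-fold lower number from compound 3 to compound 4 (0.31 log units; beyond the scatter)), the only step in this set beyond the scatter. The position on a saturated chain carbon, three bonds along the chain from an aromatic nitrogen, is therefore not silent in this assay. No evidence on the origin of this step is available.

As far as these compounds go, it remains open whether piperidin-1-yl or morpholin-4-yl at this chain end would behave like pyrrolidin-1-yl. Also open, from the compounds shown here alone, is whether a 2-(pyrrolidin-1-yl)ethyl chain would give a number where compound 2 is reported as not active.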